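A Longer Chain on Compound 3

The source may report more compounds than this note shows. Statements on the series, on what has been measured and on what is new or still open speak of the compounds shown alone.

In a functional assay on HeLa cells (Homo sapiens) for inhibition (on this read-out lower numbers stand for stronger inhibition and higher numbers for weaker inhibition), compound 1 (`Cc1cn(/C=C/C=O)c(=O)[nH]c1=O`) gives 100000 nM and compound 2 (`Nc1nc(O)c2ncn(/C=C/C=O)c2n1`) gives 50000 nM. Compound 3 (`Cc1cn(C)c(=O)n(/C=C/C=O)c1=O`) gives 15000 nM, the lowest of the three numbers and so the strongest inhibition measured so far, with its gaps to both other compounds beyond the usual scatter.

The next compound, compound 4 (`Cc1cn(COCCO)c(=O)n(/C=C/C=O)c1=O`), matches compound 3 except in one place. There, 2-hydroxyethoxy stands in place of hydrogen on a saturated chain carbon bound to an aromatic nitrogen, which turns a methyl into a (2-hydroxyethoxy)methyl (2-hydroxyethoxy in place of hydrogen on a saturated chain carbon bound to an aromatic nitrogen). For the measured compounds named here, no two measured compounds differ in only one place, so the data offer no direct precedent for this change.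

Going by the values given here, the only guide is the spread of the measured numbers, which runs from compound 3 at 15000 nM to compound 1 at 100000 nM. A small move towards a higher number, meaning slightly weaker inhibition, therefore seems the most reasonable expectation in this assay, and it would not go beyond the scatter. The expected change is a 1.3-fold higher number from compound 3 to compound 4 (0.12 log units; within the scatter). For compound 4, the estimated value is 20000 nM, with an expected range of 6000 nM to 60000 nM.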

Compound 4, half-maximal inhibitory concentration: 20000 nM
The estimate for compound 4 equals the measured number at the digits printed; the measured number falls inside the stated range.
By their numbers in this assay, from the lowest: compounds 3 and 4 (each within the scatter of the next); then compounds 2 and 1 (each within the scatter of the next).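

For the compounds shown here, this is the first step between two compounds that differ in only one place: in this assay, putting 2-hydroxyethoxy in place of hydrogen on a saturated chain carbon bound to an aromatic nitrogen gives (a 1.3-fold higher number from compound 3 to compound 4 (0.12 log units; within the scatter)). It shows that this position can carry a methyl or a (2-hydroxyethoxy)methyl with no difference beyond the scatter, even though the new group adds 4 heavy atoms, no ring and no net charge. No separate measurement is available to explain this result.

On these data alone, a single step at a single position cannot show which part of the added chain matters, so it remains open whether a plain ethoxy group, without the terminal hydroxyl, would give a similar number, or whether a terminal amine, a carboxylic acid or a longer chain would move it beyond the scatter. As far as these compounds go, it also remains open whether the same (2-hydroxyethoxy)methyl group would behave in the same way on the core of compound 2, where the surroundings of the chain differ.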